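Swapping the dimethoxyphenyl pattern on a second pyrazole chalcone

A few compounds are considered here, and "the series" means these few. Any claim that something is new, unique, unknown or untested is made for them only; others in the source may bear on it.

Three chalcone-type compounds built on a shared core have been tested in a functional assay on Huh-7 cells (Homo sapiens) for inhibition, read by sulforhodamine B assay, with a stated time of 72 h; on this read-out lower numbers stand for stronger inhibition and higher numbers for weaker inhibition. Compound 1 `COc1ccc(C(=O)/C=C/c2cn(-c3ccccc3)nc2-c2ccsc2)cc1OC` gives 2900 nM. Compound 2 `COc1ccc(OC)c(C(=O)/C=C/c2cn(-c3ccccc3)nc2-c2ccsc2)c1`, which carries a different arrangement of the two methoxy groups, gives 2100 nM. Compound 3 `COc1ccc(C(=O)/C=C/c2cn(-c3ccccc3)nc2-c2ccncc2)cc1OC` keeps the same methoxy pattern as the first compound but carries a different ring on the core; in this assay compound 3 gives 2000 nM. All three numbers lie within the usual scatter of one another, so no ordering among them can be claimed.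

The change from compound 1 to compound 2 is 2,5-dimethoxyphenyl in place of 3,4-dimethoxyphenyl on a carbonyl carbon; it produced a 1.4-fold lower number from compound 1 to compound 2 (0.14 log units; within the scatter). The change from compound 1 to compound 3 is pyridin-4-yl in place of thiophen-3-yl on an aromatic carbon; it produced a 1.5-fold lower number from compound 1 to compound 3 (0.16 log units; within the scatter).

Compound 4 `COc1ccc(OC)c(C(=O)/C=C/c2cn(-c3ccccc3)nc2-c2ccncc2)c1` has not been measured in this assay . It differs from compound 3 by 2,5-dimethoxyphenyl in place of 3,4-dimethoxyphenyl on a carbonyl carbon, which is the same change that separates compound 2 from compound 1, made at a place described in identical words. Compound 4 is therefore expected to show a step of about a 1.3-fold lower number from compound 3 to compound 4 (0.12 log units; within the scatter), resting on the size of the earlier step from compound 1 to compound 2 , which was within scatter. On that basis compound 4 is estimated to give about 1500 nM in this assay . The range for compound 4 is expected to run from 700 nM to 3500 nM, a band that reflects the scatter of the three measured numbers rather than any firm trend.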

Compound 4, half-maximal inhibitory concentration: 1700 nM
Estimate against measurement, compound 4: 1.1-fold (0.05 log units) below; the range from low to high includes it.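

In this assay, 2,5-dimethoxyphenyl in place of 3,4-dimethoxyphenyl on a carbonyl carbon gave a 1.2-fold lower number from compound 3 to compound 4 (0.07 log units; within the scatter), and this step agrees with the same change on the core of compound 1: the same change on two cores in this assay, a 1.4-fold lower number (0.14 log units; within the scatter) from compound 1 to compound 2 and a 1.2-fold lower number (0.07 log units; within the scatter) from compound 3 to compound 4, 1.2-fold (0.07 log units) apart, within the scatter of two such steps

Pyridin-4-yl in place of thiophen-3-yl on an aromatic carbon gave a 1.2-fold lower number from compound 2 to compound 4 (0.09 log units; within the scatter), and this exchange also agrees with its earlier counterpart: the same change on two cores in this assay, a 1.5-fold lower number (0.16 log units; within the scatter) from compound 1 to compound 3 and a 1.2-fold lower number (0.09 log units; within the scatter) from compound 2 to compound 4, 1.2-fold (0.07 log units) apart, within the scatter of two such steps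

Each change therefore gave steps that cannot be told apart on the two cores, with nothing in these four compounds going against that, but every step lies within the scatter, so the agreement is one between steps too small to read and does not show that either change has a real effect that carries from one core to the other.

As far as these compounds go, it remains open whether a step large enough to stand clear of the scatter would carry over in the same way. The compounds shown also leave open what an amine or a carboxylic acid in place of a methoxy group would give on either core, and whether any such step would match between the two.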